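Series notes: swapping the aryl substituent in compound 3

This account rests on a few compounds, and the source may have more. Where it says the series, first, only, none or still open, it means among the compounds named here.

Of the compounds shown here, three of the shared core have been measured so far. In a functional assay on MCF7 cells (Homo sapiens) for antiproliferative activity, read by sulforhodamine B assay, with a stated time of 48 h (a higher number here means a weaker inhibitor of growth, a lower number a stronger inhibitor of growth), compound 3 `CC(C)(C)c1ccc(-c2cc(N3CCC(CCNS(N)(=O)=O)CC3)ncn2)cc1` gives 13100 nM, the lowest number of the three; compound 1 `COc1ccc(-c2cc(N3CCC(CNS(N)(=O)=O)CC3)ncn2)cc1` gives 35300 nM and compound 2 `NS(=O)(=O)NCCC1CCN(c2cc(-c3ccccc3)ncn2)CC1` gives 53200 nM. The next compound, compound 4 `COc1ccc(-c2cc(N3CCC(CCNS(N)(=O)=O)CC3)ncn2)cc1`, differs from compound 3 in one place: methoxy in place of tert-butyl on an aromatic carbon. For the measured compounds named here, the only measured step that bears on this position is a 4.1-fold lower number from compound 2 to compound 3 (0.61 log units; beyond the scatter), which shows that removing the tert-butyl to leave hydrogen raises the number. Going by the values given here, compound 4 carries methoxy instead, a group found in compound 1, whose number sits between compound 2 and compound 3; compound 1 differs from compound 4 elsewhere as well, so no direct step exists. On these numbers compound 4 is expected to lie above compound 3, a step estimated at a 2.3-fold higher number from compound 3 to compound 4 (0.36 log units; beyond the scatter). Compound 4 is therefore estimated at 30000 nM, with a range from 12000 nM to 70000 nM.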

Compound 4, concentration for 50% growth inhibition: 56600 nM
Compound 4: middle estimate off by 1.9-fold (0.28 log units), on the low side, and the stated range covers the measured number.
By their numbers in this assay, from the lowest: compound 3; then compounds 1, 2 and 4 (each within the scatter of the next).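

In this assay the direct comparison at this aromatic carbon gives a 4.3-fold higher number from compound 3 to compound 4 (0.64 log units; beyond the scatter) and so sets tert-butyl apart from methoxy, while replacing hydrogen with methoxy gives a 1.1-fold higher number from compound 2 to compound 4 (0.03 log units; within the scatter) and so does not reproduce the step seen with tert-butyl. With methoxy held constant, (sulfamoylamino)methyl in place of sulfamoylamino on the saturated chain carbon gives a 1.6-fold higher number from compound 1 to compound 4 (0.21 log units; within the scatter) and so does not separate the two side chains in this assay. Nothing available accounts for the difference between tert-butyl and methoxy at this carbon.

Going by these compounds, whether an amine, a carboxylic acid or a trifluoromethyl group at this carbon would group with tert-butyl or with methoxy stays open. Also open, on these data alone, is whether tert-butyl would give a similar step on the side chain of compound 1.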